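Methyl to hydrogen on compound 1

The source may hold more compounds than are shown below. What is called first, only, known or untested is meant among the compounds shown, and "the series" means these compounds.

Among the compounds with values here, in a functional assay on HCT-116 cells (Homo sapiens) for inhibition, read by MTT assay, with a stated time of 72 h (on this read-out higher numbers stand for weaker inhibition and lower numbers for stronger inhibition), compound 1 (`COc1cc2c(Oc3ccc(NC(=O)c4nn(-c5ccccc5C)cc(C)c4=O)cc3F)ccnc2cc1OCCCC(=O)NO`) gives 2040 nM, the higher of the two numbers so far, and compound 2 (`COc1cc2c(Oc3ccc(NC(=O)c4nn(-c5ccccc5)cc(C)c4=O)cc3F)ccnc2cc1OCCCC(=O)NO`) gives 660 nM. Compound 3 (`COc1cc2c(Oc3ccc(NC(=O)c4nn(-c5ccccc5C)ccc4=O)cc3F)ccnc2cc1OCCCC(=O)NO`) is unmeasured. Its change is hydrogen in place of methyl on an aromatic carbon of the six-membered aromatic ring with 2 nitrogen. Within the data shown here, the one measured step bearing on it, a 3.1-fold lower number from compound 1 to compound 2 (0.49 log units; beyond the scatter), is the same kind of swap at another place, so support is thin. A modest move toward a lower number is expected, estimated as a 2.0-fold lower number from compound 1 to compound 3 (0.31 log units; beyond the scatter). For compound 3 the estimated value is 1000 nM, with an expected range of 350 nM to 2600 nM.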

Compound 3, half-maximal inhibitory concentration: 3980 nM
For compound 3 the middle estimate is 4.0-fold (0.60 log units) below the measured one; measured number above the stated range.
By their numbers in this assay, from the lowest: compound 2; then compounds 1 and 3 (each within the scatter of the next).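

Hydrogen in place of methyl on this carbon, opposite the ring nitrogen, gives a 2.0-fold higher number from compound 1 to compound 3 (0.29 log units; within the scatter) in this assay, so the swap has no effect here that can be told from the scatter. The same kind of swap on the 2-methylphenyl group gave a 3.1-fold lower number from compound 1 to compound 2 (0.49 log units; beyond the scatter), beyond the scatter, so that step does not carry over to this position. Nothing on hand accounts for the difference between the two places.

The compounds shown leave open how an ethyl group or an amine on this carbon would read. Also open, on these data alone, is how hydrogen here would read alongside the phenyl group of compound 2.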